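The source may hold more compounds than are shown below. What is called first, only, known or untested is meant among the compounds shown, and "the series" means these compounds.

Three compounds have been measured in a functional assay on HeLa cells (Homo sapiens) for cytotoxicity, read by MTT assay, with a stated time of 24 h; on this read-out higher numbers stand for weaker inhibition and lower numbers for stronger inhibition:

Compound 1 `COc1cccc(/C=C2\SC(=O)N(Cc3ccc(C(=O)O)cc3)C2=O)c1` gives 48000 nM.
Compound 2 `COc1ccc(/C=C2\SC(=O)N(Cc3ccc(C(=O)O)cc3)C2=O)cc1` gives 40000 nM.
Compound 3 `O=C(O)c1ccc(CN2C(=O)S/C(=C\c3cccnc3)C2=O)cc1` gives 88000 nM.

Compound 3 sits at the high end of these three numbers. The step of a 1.8-fold higher number from compound 1 to compound 3 (0.26 log units; within the scatter) stays within the scatter, whereas the step of a 2.2-fold higher number from compound 2 to compound 3 (0.34 log units; beyond the scatter) goes a little beyond it, and the step of a 1.2-fold lower number from compound 1 to compound 2 (0.08 log units; within the scatter) between the two methoxyphenyl compounds is itself within the scatter. All three compounds share one core and differ only in the aryl group on a double-bonded chain carbon bound to a double-bonded ring carbon.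

Compound 4 `O=C(O)c1ccc(CN2C(=O)S/C(=C\c3ccco3)C2=O)cc1` changes that same position again: furan-2-yl in place of pyridin-3-yl on a double-bonded chain carbon bound to a double-bonded ring carbon. Among the compounds with values here, no measured step exchanges pyridin-3-yl for furan-2-yl, so the only guidance comes from the aryl exchanges already seen at this place, a 1.8-fold higher number from compound 1 to compound 3 (0.26 log units; within the scatter) and a 2.2-fold higher number from compound 2 to compound 3 (0.34 log units; beyond the scatter), which were small or modest. On that basis compound 4 is expected to move little from compound 3 in this assay, and the expected step of a 1.3-fold lower number from compound 3 to compound 4 (0.10 log units; within the scatter) is not expected to clear the scatter with confidence. For compound 4 the estimate in this assay is 70000 nM, with a range from 30000 nM to 160000 nM.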

Compound 4, half-maximal inhibitory concentration: 80000 nM
For compound 4 the middle estimate is 1.1-fold (0.06 log units) below the measured one; the range from low to high includes it.
By their numbers in this assay, from the lowest: compounds 2, 1, 4 and 3 (each within the scatter of the next, the first and the last beyond it).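

In this assay, within the data shown here, the exchange of the six-membered pyridin-3-yl for the five-membered furan-2-yl is the first step at this position that changes ring size and hetero atom together, and it stays well within the scatter (a 1.1-fold lower number from compound 3 to compound 4 (0.04 log units; within the scatter)). Furan-2-yl also stays within the scatter of both methoxyphenyl groups (a 2.0-fold higher number from compound 2 to compound 4 (0.30 log units; within the scatter); a 1.7-fold higher number from compound 1 to compound 4 (0.22 log units; within the scatter)), although the step from compound 2 to compound 4 lies at the edge of it, so compound 4 falls in with all three earlier compounds and adds no new separation among them; the only step beyond the scatter in this set remains the one between compound 2 and compound 3. No measurement is available here that would explain why the number in this assay stays where it does across these aryl exchanges.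

From the compounds shown here alone, all four compounds carry an aromatic ring on a double-bonded chain carbon bound to a double-bonded ring carbon, so it remains open whether an amine, a longer chain or a saturated ring such as cyclohexyl in that place would give a step clearly beyond the scatter. The same holds for an unsubstituted phenyl or a thiophen-2-yl, which would show whether the methoxy group or the hetero atom matters at all.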